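The source may hold more compounds than are shown below. What is called first, only, known or untested is meant among the compounds shown, and "the series" means these compounds.

Measured in an ADME assay on HMEC-1 cells (Homo sapiens) for cytotoxicity, read by MTT assay, with a stated time of 72 h; on this read-out higher numbers stand for weaker inhibition and lower numbers for stronger inhibition:
- Compound 1 `CC[C@H]1C[C@@]23OC(=O)C(=C2O)C(=O)[C@]2(CC)[C@@H](C=C[C@@H]4[C@@H](O[C@H]5C[C@@H](O)[C@H](NC(=O)c6[nH]c(Cl)cc6Cl)[C@@H](C)O5)[C@@H](C)CC[C@@H]42)CCCC/C=C/[C@@]3(C)C=C1C(=O)O`: 9000 nM
- Compound 2 `CC[C@H]1C[C@@]23OC(=O)C(=C2O)C(=O)[C@]2(CC)[C@@H](C=C[C@@H]4[C@@H](O[C@H]5C[C@@H](O)[C@H](NC(=O)c6[nH]cc(Br)c6Br)[C@@H](C)O5)[C@@H](C)CC[C@@H]42)CCCC/C=C/[C@@]3(C)C=C1C(=O)O`: 3000 nM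

Compound 2 holds the lower of the two numbers. Compound 3 `CC[C@H]1C[C@@]23OC(=O)C(=C2O)C(=O)[C@]2(CC)[C@@H](C=C[C@@H]4[C@@H](O[C@H]5C[C@@H](O)[C@H](NC(=O)c6[nH]ccc6Br)[C@@H](C)O5)[C@@H](C)CC[C@@H]42)CCCC/C=C/[C@@]3(C)C=C1C(=O)O` differs from it in one place: hydrogen in place of bromo on an aromatic carbon. Among the measured compounds shown here, only one measured step bears on this, the modest 3.0-fold lower number from compound 1 to compound 2 (0.48 log units; beyond the scatter), which exchanges chlorine for bromine and removes no halogen, so it is a loose guide. With bromine lost, a modest move towards a higher number is expected. The expected step is a 2.3-fold higher number from compound 2 to compound 3 (0.37 log units; beyond the scatter). Compound 3 is estimated at 7000 nM, with an expected range from 2500 nM to 18000 nM.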

Compound 3, half-maximal inhibitory concentration: 43000 nM
Beside the measured number, compound 3's estimate is 6.1-fold (0.79 log units) below it; the whole stated range lies below it.
By their numbers in this assay, from the lowest: compound 2; then compound 1; then compound 3.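

In this assay the bromo group two ring bonds from the ring nitrogen counts for far more than the exchange of halogens had suggested: hydrogen in its place gives a 14-fold higher number from compound 2 to compound 3 (1.16 log units; beyond the scatter). The ring with one bromine also gives a higher number than the ring with two chlorines, at a 4.8-fold higher number from compound 1 to compound 3 (0.68 log units; beyond the scatter). Nothing available explains why this position matters so much. Still open, going by these compounds, is whether a methyl group or a nitrile at this position would hold the number near that of compound 2. Also open, on these data alone, is what removing the other bromo group alone would do.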